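A few compounds are considered here, and "the series" means these few. Any claim that something is new, unique, unknown or untested is made for them only; others in the source may bear on it.

Going by the values given here, compound 3 `CC(=O)Nc1ccc2c(c1)S(=O)(=O)N=C(c1c(O)c(-c3cccs3)nn(CCC(C)C)c1=O)N2` gives 0.055 h in an in vitro ADME assay on microsomes from liver (Homo sapiens) for metabolic stability, tested at 5 uM (a lower number here means that the compound disappears faster, a higher number that the compound lasts longer), the lowest of the three numbers measured so far. Compound 1 `CC(C)CCn1nc(-c2cccs2)c(O)c(C2=NS(=O)(=O)c3cc(OC(C)C(N)=O)ccc3N2)c1=O` gives 0.217 h in this assay, and compound 2 `CC(C)CCn1nc(-c2cccs2)c(O)c(C2=NS(=O)(=O)c3cc(OC(C)(C)C(N)=O)ccc3N2)c1=O` gives 0.35 h in this assay. The step of a 3.9-fold lower number from compound 1 to compound 3 (0.60 log units; beyond the scatter) and the step of a 6.4-fold lower number from compound 2 to compound 3 (0.80 log units; beyond the scatter) both run downward, while the step of a 1.6-fold higher number from compound 1 to compound 2 (0.21 log units; within the scatter) is small. Compound 4 `CC(=O)c1ccc2c(c1)S(=O)(=O)N=C(c1c(O)c(-c3cccs3)nn(CCC(C)C)c1=O)N2` differs from compound 3 in a single place: acetyl in place of acetamido on an aromatic carbon. Among the compounds with values here, none of the measured steps alters an acetamido group into something else; the two steps that lead to compound 3 bring the acetamido group in for the 1-carbamoylethoxy or the 1-carbamoyl-1-methylethoxy group, and the remaining step adds a methyl on a saturated chain carbon. These steps give no direct guide to the present change, so the expected step of a 1.5-fold higher number from compound 3 to compound 4 (0.16 log units; within the scatter) is small, with no direction that can be called beyond the scatter. Compound 4 is therefore estimated to give 0.08 h in this assay, within an expected range from 0.03 h to 0.22 h.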

Compound 4, half-life: 0.0717 h
Compound 4: the middle estimate sits 1.1-fold (0.05 log units) above what was measured, and the stated range covers the measured number.
By their numbers in this assay, from the lowest: compounds 3 and 4 (each within the scatter of the next); then compounds 1 and 2 (each within the scatter of the next).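

At this aromatic carbon, acetyl in place of acetamido gives a 1.3-fold higher number from compound 3 to compound 4 (0.12 log units; within the scatter) in this assay, so losing the hydrogen-bond donor of the acetamido group leaves no readable change in half-life. Acetyl, like acetamido, stands apart from the two carbamoyl side chains: replacing 1-carbamoyl-1-methylethoxy gives a 4.9-fold lower number from compound 2 to compound 4 (0.69 log units; beyond the scatter) and replacing 1-carbamoylethoxy gives a 3.0-fold lower number from compound 1 to compound 4 (0.48 log units; beyond the scatter), which shows that the lower half-life of compound 3 does not depend on the amide nitrogen of its acetamido group. No measurement shown explains the gap between the carbamoyl side chains and these two shorter groups.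

Still open, going by these compounds, is which part of the side chains matters, and a plain methoxy group on this carbon would begin to separate the ether oxygen from the carbamoyl end. Equally open, on these data alone, is where an amine or a carboxylic acid at this place would fall.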